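This account rests on a few compounds, and the source may have more. Where it says the series, first, only, none or still open, it means among the compounds named here.

Working notes on the series. Two compounds of the shared core carry numbers: compound 1 `Nc1ccccc1NC(=O)c1ccc(CSC(=S)N2CCN(Cc3ccncc3)CC2)cc1` and compound 2 `CN(Cc1cccnc1)C(=S)SCc1ccc(C(=O)Nc2ccccc2N)cc1`. In a functional assay on A-375 cells (Homo sapiens) for antiproliferative activity, read by CCK-8 assay, with a stated time of 72 h, tested at 2 uM (a higher number here means a stronger effect of the compound at the concentration tested, a lower number a weaker effect), compound 1 gives 33.1%. In this assay compound 2 gives 39.4%. Compound 1 stands at the smaller of the two figures, but the gap to compound 2 is within the usual scatter, so the two values show no real separation. Within the data shown here, no pair of measured compounds differs in a single place, so no measured step is available to lean on.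

Compound 3 `Nc1ccccc1NC(=O)c1ccc(CSC(=S)N2CCN(Cc3ccccc3)CC2)cc1` has not been measured in this assay. It differs from compound 1 in one place:

phenyl in place of pyridin-4-yl on a saturated chain carbon bound to an amine nitrogen in a ring

The amine nitrogen in a ring and its saturated chain carbon are kept; only the aromatic ring on that carbon changes. Nothing measured bears directly on a pyridin-4-yl to phenyl exchange at this position. The step of a number 3.9 percentage points higher from compound 1 to compound 3 (within the scatter) is therefore expected to stay within the scatter, with no direction claimed. Compound 3 is expected to give about 37% in this assay, estimated between 22% and 55%.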

Compound 3, a percentage reported as inhibition, at one concentration (the size of the read-out at that concentration, not a potency): 10.6%
Compound 3: the middle estimate sits 26.4 percentage points above what was measured; measured number below the stated range.
By their numbers in this assay, from the lowest: compound 3; then compounds 1 and 2 (each within the scatter of the next).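

In this assay, among these compounds, phenyl in place of pyridin-4-yl on a saturated chain carbon bound to an amine nitrogen in a ring gives a number 22.5 percentage points lower from compound 1 to compound 3 (beyond the scatter) and so provides the first single-place step. This position is therefore not indifferent to the aromatic ring it carries, even though both rings are six-membered, aromatic and of the same heavy-atom count; the counted difference is one ring nitrogen and its one hydrogen-bond acceptor, with the rest of compound 1 kept. No measurement on hand accounts for the size or direction of this step, and the link between that counted difference and the read-out remains unexplained.

The compounds shown leave open whether the read-out follows the presence of a ring nitrogen as such, which pyridin-2-yl or pyrimidin-4-yl at the same carbon would test, or whether a phenyl ring carrying a hydroxyl or methoxy group would recover the number of compound 1. They also leave open whether a longer chain, such as an ethyl link between the amine nitrogen and the aromatic ring, preserves the step.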